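A few compounds are considered here, and "the series" means these few. Any claim that something is new, unique, unknown or untested is made for them only; others in the source may bear on it.

Compound 1 `O=C(CSc1nc(Nc2ccccc2)c2ccccc2n1)Nc1cccc(Br)c1` gives 10100 nM in a functional assay on NCI-H1975 cells (Homo sapiens) for inhibition, read by MTT assay, with a stated time of 72 h; on this read-out higher numbers stand for weaker inhibition and lower numbers for stronger inhibition. Compound 2 `C=CC(=O)Nc1cccc(NC(=O)CSc2nc(Nc3ccccc3)c3ccccc3n2)c1` gives 8120 nM. Compound 3 `O=C(CSc1nc(Nc2ccccc2)c2ccccc2n1)Nc1ccc(F)cc1` gives 16500 nM.

Among these three numbers compound 3 stands highest, so its inhibition is the weakest measured; the step of a 1.6-fold higher number from compound 1 to compound 3 (0.21 log units; within the scatter) stays within the scatter, while the step of a 2.0-fold higher number from compound 2 to compound 3 (0.31 log units; beyond the scatter) goes a little beyond it. Compound 4 `O=C(CSc1nc(Nc2ccccc2)c2ccccc2n1)Nc1ccc(F)c(Cl)c1` differs from compound 3 by one change: chloro in place of hydrogen on an aromatic carbon. Both measured steps that bear on this change alter the same phenyl ring and were small. Going by the values given here, no measured step adds a chloro anywhere. The expectation for compound 4 is therefore a step of a 1.4-fold lower number from compound 3 to compound 4 (0.14 log units; within the scatter), with no change beyond the scatter. Compound 4 is estimated at 12000 nM, between 5000 nM and 30000 nM.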

Compound 4, half-maximal inhibitory concentration: 9390 nM
Estimate against measurement, compound 4: 1.3-fold (0.11 log units) above; the range from low to high includes it.
By their numbers in this assay, from the lowest: compounds 2, 4, 1 and 3 (each within the scatter of the next, the first and the last beyond it).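

In this assay, chloro on the 4-fluorophenyl ring brings no change beyond the scatter (a 1.8-fold lower number from compound 3 to compound 4 (0.24 log units; within the scatter)), so this place takes a chloro while the fluoro stays. The resulting 3-chloro-4-fluorophenyl group cannot be told apart from 3-bromophenyl (a 1.1-fold lower number from compound 1 to compound 4 (0.03 log units; within the scatter)) or from 3-((vinylcarbonyl)amino)phenyl (a 1.2-fold higher number from compound 2 to compound 4 (0.06 log units; within the scatter)). No measurement shown here accounts for these readings. Still open, as far as these compounds go, is whether an amine or a carboxylic acid at this place would move the number beyond the scatter, and whether chloro without the fluoro would read the same.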